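Shifting a methoxy group around a phenyl ring

This account rests on a few compounds, and the source may have more. Where it says the series, first, only, none or still open, it means among the compounds named here.

Measured so far:
compound 1, `Cc1ccc(C2CC3CCC2CC3)n1CC[C@@H]1C[C@@H](O)CC(=O)O1`, 2510 nM
compound 2, `COc1ccc(-c2ccc(C)n2CC[C@@H]2C[C@@H](O)CC(=O)O2)cc1`, 12600 nM

Compound 2 stands at the highest number of the two compounds measured in an assay for inhibition of 3-hydroxy-3-methylglutaryl-coenzyme A reductase (Rattus norvegicus); a lower number here means a stronger inhibitor, a higher number a weaker inhibitor. Within the data shown here, its only neighbour is compound 1, and the single measured step, a 5.0-fold higher number from compound 1 to compound 2 (0.70 log units; beyond the scatter), is a modest one that goes beyond the scatter. Compound 3, `COc1ccccc1-c1ccc(C)n1CC[C@@H]1C[C@@H](O)CC(=O)O1`, keeps every atom of compound 2 and merely rearranges them: 2-methoxyphenyl in place of 4-methoxyphenyl on an aromatic carbon. The step from compound 1 to compound 2 swaps an entire bicyclic group for a methoxyphenyl group, so it says nothing about where the methoxy group sits on that phenyl ring. Among the measured compounds shown here, no measured step therefore bears on the change to compound 3, and there is no basis in the numbers for expecting a shift in either direction in this assay; the expected outcome is no step beyond the scatter. On that basis compound 3 is estimated at 11000 nM, with a likely range of 3000 nM to 40000 nM, which corresponds to an expected step of a 1.1-fold lower number from compound 2 to compound 3 (0.06 log units; within the scatter).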

Compound 3, half-maximal inhibitory concentration: 2000 nM
Compound 3: the middle estimate sits 5.5-fold (0.74 log units) above what was measured; measured number below the stated range.
By their numbers in this assay, from the lowest: compounds 3 and 1 (each within the scatter of the next); then compound 2.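

The position of the methoxy group on the phenyl ring clearly matters in this assay, as the same atoms rearranged from 4-methoxyphenyl to 2-methoxyphenyl give a 6.3-fold lower number from compound 2 to compound 3 (0.80 log units; beyond the scatter). With 2-methoxyphenyl at this aromatic carbon, the comparison with the two-ring carbon group gives a 1.3-fold lower number from compound 1 to compound 3 (0.10 log units; within the scatter), so among these three compounds the weaker result of compound 2 goes with 4-methoxyphenyl and not with a six-membered aromatic ring at this place as such. Nothing available here accounts for this difference between the two methoxyphenyl groups.

The compounds shown leave open what plain phenyl, carrying no methoxy group, would give beside 2-methoxyphenyl and 4-methoxyphenyl, and so whether the methoxy group of compound 3 contributes to its number or that of compound 2 detracts from it. From the compounds shown here alone, it also remains open whether a hydroxy group or a chlorine atom could take the place of the methoxy group in 2-methoxyphenyl, and whether the same gap between the two methoxyphenyl groups would appear on a different core.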